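Bromine in place of the sulfur-bearing group at the aromatic carbon

This account rests on a few compounds, and the source may have more. Where it says the series, first, only, none or still open, it means among the compounds named here.

For the measured compounds named here, compound 2 `CC1(C)C=C(n2ccccc2=O)c2cc(C(=N)S)ccc2O1` gives 6.21 in a functional assay (aorta) with Rattus norvegicus as the target (a higher number here means a more potent compound, by a factor of ten per unit of this negative logarithm, a lower number a less potent compound), and stands lowest of the two numbers so far; its nearest neighbour, compound 1 `CCC(=O)c1ccc2c(c1)C(n1ccccc1=O)=CC(C)(C)O2`, gives 6.63 in this assay. Going by the values given here, the one measured step, a number 0.42 log units lower from compound 1 to compound 2 (beyond the scatter), alters the same aromatic carbon: the group of 3 heavy atoms (1 carbon, 1 nitrogen, 1 sulfur; no ring) in place of the group of 4 heavy atoms (3 carbon, 1 oxygen; no ring) lowers the number modestly. Compound 3 `CC1(C)C=C(n2ccccc2=O)c2cc(Br)ccc2O1`, not yet measured, carries bromo at that carbon: one bromine atom in place of a group of 3 heavy atoms (1 carbon, 1 nitrogen, 1 sulfur; no ring), on an aromatic carbon. Among the compounds with values here, only that single step bears on the change, and it shows the exchange at this carbon has so far moved the number only modestly, so a small gain or no change beyond the scatter is expected, a number 0.29 log units higher from compound 2 to compound 3 (within the scatter). Compound 3 is therefore expected to give 6.5 in this assay, with an estimated range from 5.8 to 7.2.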

Compound 3, logarithm of the reciprocal of the active concentration, log(1/C): 7.84
Compound 3: middle estimate off by 1.34 log units, on the low side, and the stated range ends below it.
By their numbers in this assay, from the lowest: compound 2; then compound 1; then compound 3.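

At this aromatic carbon, the first step had suggested a modest sensitivity, but in this assay bromo stands clearly above both earlier groups: the sulfur-bearing group (a number 1.63 log units higher from compound 2 to compound 3 (beyond the scatter)) and propanoyl (a number 1.21 log units higher from compound 1 to compound 3 (beyond the scatter)). The position is therefore far more responsive to its substituent than the earlier pair showed, and among these three compounds the highest number comes with the single-atom group, which has no hydrogen-bond donors or acceptors. Nothing available explains the size of this gain.

From the compounds shown here alone, it remains open whether the rise is particular to bromo or would also appear with chloro, a nitrile or trifluoromethyl at this carbon. An amine or a carboxylic acid there would test whether the order among these three compounds extends to other groups.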